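Ethylsulfonyl added to compound 2: clearance notes

A few compounds are considered here, and "the series" means these few. Any claim that something is new, unique, unknown or untested is made for them only; others in the source may bear on it.

compound 1 `CCn1cnc2c(-c3ccc(F)c(-c4cnn(C)c4)c3)cnnc21` gives 47 mL.min-1.g-1
compound 2 `CCn1cnc2c(-c3ccnc(Oc4ccccc4)c3)cnnc21` gives 51 mL.min-1.g-1

In an ADME assay on microsomes from liver (Homo sapiens) for metabolic stability (on this read-out higher numbers stand for fast clearance and lower numbers for slow clearance), compound 2 lies within the scatter of compound 1, so the two numbers do not separate. Compound 3 `CCn1cnc2c(-c3ccnc(Oc4cccc(S(=O)(=O)CC)c4)c3)cnnc21` carries ethylsulfonyl in place of hydrogen on an aromatic carbon of compound 2 (ethylsulfonyl in place of hydrogen on an aromatic carbon). Among the measured compounds shown here, no measured step covers such a change, so the expectation is a judgement only: a moderate fall in clearance, with no move beyond the scatter still possible. The expected step is a downward one (a 1.8-fold lower number from compound 2 to compound 3 (0.26 log units; within the scatter)). The estimate for compound 3 is 28 mL.min-1.g-1 (expected range 12 mL.min-1.g-1 to 60 mL.min-1.g-1).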

Compound 3, intrinsic clearance in microsomes in the Homo sapiens assay: < 8 mL.min-1.g-1
Compound 3: a limit, no number; the forecaster's own chance of this, stated with the estimate: 5%; middle value at least 3.5-fold (0.54 log units) away from the limit.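

In the Homo sapiens assay, ethylsulfonyl in place of hydrogen on an aromatic carbon, meta to a large group, gives a clear change: an at least 6.3-fold lower number from compound 2 to compound 3 (0.80 log units; beyond the scatter). Going by these compounds, the result for compound 3 is a limit, not a number, so the full size of the step stays unknown: the limit of < 8 mL.min-1.g-1 in the Homo sapiens assay, at which 1 of the 3 values shown sits. In a physicochemical assay for lipophilicity (on this read-out higher numbers stand for higher lipophilicity and lower numbers for lower lipophilicity), compound 2 gives 2.6 and compound 3 gives 1.6. The same change lowers the distribution coefficient, which may account for part of the fall in clearance: the measured distribution coefficient of compound 2, 2.6, and of compound 3, 1.6, a number 1.00 log units lower (beyond the scatter)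

Open, on these data alone, is whether the fall belongs to ethylsulfonyl itself or would also follow a carboxylic acid or an amine on the same carbon.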